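This account rests on a few compounds, and the source may have more. Where it says the series, first, only, none or still open, it means among the compounds named here.

Measured compounds:
Compound 1, `Nc1cc(N)c2nc(-c3ccccc3)c(NCc3ccc(Cl)c(Cl)c3)nc2c1`, gives 2140 nM in a functional assay on LOX IMVI cells (Homo sapiens) for inhibition, read by sulforhodamine B assay, with a stated time of 48 h; on this read-out higher numbers stand for weaker inhibition of growth and lower numbers for stronger inhibition of growth.
Compound 2, `Nc1cc(N)c2nc(-c3ccccc3)c(Oc3ccc(F)cc3)nc2c1`, gives 43700 nM.
Compound 3, `Nc1cc(N)c2nc(-c3ccccc3)c(Sc3ccc(Cl)c(Cl)c3)nc2c1`, gives 7410 nM.

Among these three, compound 1 has the lowest number, with compound 3 a step away and compound 2 furthest. For the measured compounds named here, the one step between two measured compounds that differ in a single place, a 5.9-fold lower number from compound 2 to compound 3 (0.77 log units; beyond the scatter), changes both the linking atom and the ring substituents at once, so it does not isolate the effect of the ring substituents alone.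

Compound 4, `COc1ccc(CNc2nc3cc(N)cc(N)c3nc2-c2ccccc2)cc1OC`, is related to compound 1 by a single change: 3,4-dimethoxyphenyl in place of 3,4-dichlorophenyl on a saturated chain carbon bound to a nitrogen on an aromatic ring. Going by the values given here, no measured pair shows this change, so nothing in the data speaks directly to it. The comparison between compound 2 and compound 3 suggests that the substituents on this ring can matter, and the account therefore expects a modest step, most likely toward a higher number, expressed as a 2.8-fold higher number from compound 1 to compound 4 (0.45 log units; beyond the scatter). For compound 4 the estimated value is 6000 nM, with a range from 1500 nM to 25000 nM.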

Compound 4, concentration for 50% growth inhibition: 3090 nM
The estimate for compound 4 lay 1.9-fold (0.29 log units) above the measured number, and the stated range covers the measured number.
By their numbers in this assay, from the lowest: compounds 1 and 4 (each within the scatter of the next); then compound 3; then compound 2.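

In this assay, the exchange on a saturated chain carbon bound to a nitrogen on an aromatic ring gives a 1.4-fold higher number from compound 1 to compound 4 (0.16 log units; within the scatter), so this assay does not separate 3,4-dimethoxyphenyl from 3,4-dichlorophenyl at this position. The earlier step changed the linking atom and the ring substituents together, whereas this pair keeps the link fixed and alters only the ring substituents, and the two numbers remain within the usual scatter of each other. Nothing available here explains this outcome.

The compounds shown leave open whether an unsubstituted phenyl ring or a ring bearing a carboxylic acid would also stay within the scatter of compound 1. They also leave open how a longer chain between the nitrogen and the ring would read in this assay.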